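From Diethylamino to Chloro: What Compound 4 Might Show

A few compounds are considered here, and "the series" means these few. Any claim that something is new, unique, unknown or untested is made for them only; others in the source may bear on it.

Compound 1 `Cc1c(Cc2ccccc2)c(NNC(=O)Nc2cc(Cl)nc(Cl)c2)nc2c1cnn2C`: 13600 nM
Compound 2 `CCN(CC)c1cc(NC(=O)NNc2cc(-c3ccc(F)cc3)c3cnn(C)c3n2)cc(Cl)n1`: 29400 nM
Compound 3 `Cc1cc(NNC(=O)Nc2cc(Cl)nc(Cl)c2)nc2c1c(C)nn2C`: > 100000 nM (a limit, not a number)

These three compounds were tested in a functional assay on HCT-116 cells (Homo sapiens) for cytotoxicity, read by MTT assay, with a stated time of 48 h, in the presence of a further agent that is not named here; on this read-out lower numbers stand for an effect already at smaller amounts and higher numbers for an effect only at larger amounts of compound. Compound 3 gave only the limit of the assay, (the limit of > 100000 nM in this assay, at which 1 of the 3 values shown sits). Of the two numbers, compound 2 has the highest; the nearest is compound 1 with a lower number, a gap beyond the usual scatter. Compound 4 `Cn1ncc2c(-c3ccc(F)cc3)cc(NNC(=O)Nc3cc(Cl)nc(Cl)c3)nc21` has not yet been measured. It differs from compound 2 at one place: chloro in place of diethylamino on an aromatic carbon. Within the data shown here, no measured pair isolates this change, since compound 1 and compound 3 carry the chloro but differ from compound 4 elsewhere. The direction is therefore open, and a modest step either way, or none beyond the scatter, is expected. Compound 4 is estimated at 22000 nM, within 6000 nM to 90000 nM. The expected step is a 1.3-fold lower number from compound 2 to compound 4 (0.13 log units; within the scatter).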

Compound 4, half-maximal effective concentration: 8210 nM
Beside the measured number, compound 4's estimate is 2.7-fold (0.43 log units) above it; the range from low to high includes it.
By their numbers in this assay, from the lowest: compounds 4 and 1 (each within the scatter of the next); then compound 2. At a limit, above all of these: compound 3.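

In this assay, putting chloro in place of diethylamino on this aromatic carbon, next to the ring nitrogen, gives a 3.6-fold lower number from compound 2 to compound 4 (0.55 log units; beyond the scatter). Among these compounds, this is the first direct reading of the change, and it shows that the five heavy atoms of diethylamino are not needed at this place for an effect at these amounts; the single chlorine goes with the lower number. Nothing measured here accounts for the step. This rests on one pair with two groups at this place. Where a smaller amine such as dimethylamino, or a methoxy group, would fall remains open.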